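The source may hold more compounds than are shown below. What is called first, only, known or untested is meant among the compounds shown, and "the series" means these compounds.

Measured so far in an ADME assay on microsomes from liver (Rattus norvegicus) for metabolic stability, read by LC-MS, with a stated time of 30 min, tested at 0.5 uM; a higher number here means that more of the compound is left, a lower number that less of the compound is left:
- Compound 1 `c1ccc(-c2cc(-c3csc(N=C4NCCCN4)n3)cs2)cc1`: 30%
- Compound 2 `c1ccc(-c2nc(-c3csc(N=C4NCCCN4)n3)cs2)cc1`: 31%

Only these two compounds have been measured in this assay. Compound 2 stands at 31%, and compound 1 stands at 30%. The two values lie within the usual scatter of each other, so neither compound can be set apart from the other on these numbers.

The next compound to be measured is compound 3 `c1cncc(-c2nc(-c3csc(N=C4NCCCN4)n3)cs2)c1`. It carries pyridin-3-yl in place of phenyl on an aromatic carbon of the five-membered aromatic ring with 1 nitrogen and 1 sulfur (pyridin-3-yl in place of phenyl on an aromatic carbon).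

Among the measured compounds shown here, no measured pair in this small set shows what such an exchange does, so the expectation has little to rest on and its range is kept wide. A moderate upward step in this assay, somewhat beyond the scatter, is expected from the starting point of compound 2 at 31%. The expected step is a number 14 percentage points higher from compound 2 to compound 3 (beyond the scatter). For compound 3 the estimated value is 45%, with an expected range from 25% to 68%.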

Compound 3, percent of the compound remaining: 19%
Estimate against measurement, compound 3: 26 percentage points above, and the stated range ends above it.
By their numbers in this assay, from the lowest: compound 3; then compounds 1 and 2 (each within the scatter of the next).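

The exchange of phenyl for pyridin-3-yl on an aromatic carbon of the five-membered aromatic ring with 1 nitrogen and 1 sulfur comes out in this assay as a number 12 percentage points lower from compound 2 to compound 3 (beyond the scatter). Compounds 1 and 2 both carry phenyl at this place, so they gave no reading of it; this pair shows that the group there is not indifferent, since a swap that keeps the heavy-atom count and puts one ring nitrogen in place of a ring carbon leaves less of the compound after the incubation. Nothing measured here bears on why this exchange lowers the number.

This single pair leaves open whether the step belongs to a ring nitrogen in general or to pyridin-3-yl in particular, and a pyridin-2-yl or pyridin-4-yl group would separate those two readings. It also leaves open how a phenyl ring carrying a fluorine atom, a methoxy group or an amine would stand in this assay, and so whether any group at this place can lift the number above that of the phenyl compounds.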